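Sulfanyl for sulfonyl: working notes on compound 3

The source may report more compounds than this note shows. Statements on the series, on what has been measured and on what is new or still open speak of the compounds shown alone.

Among the measured compounds shown here, in a functional assay on DU-145 cells (Homo sapiens) for inhibition, read by trypan blue exclusion, with a stated time of 96 h (a lower number here means a stronger inhibitor of growth, a higher number a weaker inhibitor of growth), compound 1 (`O=C(/C(=C\c1ccccc1OCc1ccccc1)SCc1ccc(Cl)c(Cl)c1)c1ccc(Cl)cc1`) gives 10000 nM and compound 2 (`COc1ccc(S(=O)(=O)/C(=C/c2ccccc2OCc2ccccc2)C(=O)c2ccc(Cl)cc2)cc1`) gives 1000 nM as the lower of the two numbers so far. Compound 3 (`O=C(/C(=C\c1ccccc1OCc1ccccc1)Sc1ccc(Br)cc1)c1ccc(Cl)cc1`) carries (4-bromophenyl)sulfanyl in place of (4-methoxyphenyl)sulfonyl on a double-bonded chain carbon bound to a carbonyl carbon and a double-bonded chain carbon. For the measured compounds named here, only one measured step bears on this: a 10-fold lower number from compound 1 to compound 2 (1.00 log units; beyond the scatter) with (4-methoxyphenyl)sulfonyl replacing (3,4-dichlorobenzyl)sulfanyl at that place. Going by the values given here, compound 3 returns to a sulfanyl group there, though not the one in compound 1, and no measured pair isolates the aryl group. A higher number is therefore expected, with part of that earlier step given back: the expected change is a 4.0-fold higher number from compound 2 to compound 3 (0.60 log units; beyond the scatter) in this assay terms. Compound 3 is estimated at 4000 nM (range 1200 nM to 12000 nM).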

Compound 3, concentration for 50% growth inhibition: 10000 nM
Compound 3: middle estimate off by 2.5-fold (0.40 log units), on the low side; the measured number falls inside the stated range.
By their numbers in this assay, from the lowest: compound 2; then compounds 1 and 3 (each within the scatter of the next).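

In this assay the move back to a sulfanyl group at this place gives up the whole of the lower number seen with the sulfonyl group (a 10-fold higher number from compound 2 to compound 3 (1.00 log units; beyond the scatter)). The aryl or benzyl group on the sulfur makes no readable difference between these two sulfanyl compounds (no change at the digits printed from compound 1 to compound 3 (within the scatter)), so 4-bromophenyl and 3,4-dichlorobenzyl do not separate here, and among the three compounds only the sulfonyl compound 2 stands apart. Nothing at hand accounts for this step.

Still open, going by these compounds, is how the step divides between the sulfonyl group and the 4-methoxyphenyl, as compound 2 and compound 3 differ in both within one group, and a (4-bromophenyl)sulfonyl group would separate the two. Also open, on these data alone, is how an amine or a carboxylic acid on the aryl ring would read at this place.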